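The compounds below may be only part of what the source reports. "The series", "measured", "known", "first", "only" and "open" are said of these compounds alone.

Measured compounds so far:
- compound 1 `COc1cc(/C=C/c2nc(Nc3ccc(C)cc3)c3sccc3n2)cc(OC)c1OC`; in a functional assay on L02 cells (Homo sapiens) for inhibition, read by Griess assay, with stated times of 1 h and 24 h (on this read-out higher numbers stand for weaker inhibition and lower numbers for stronger inhibition), compound 1 gives < 40000 nM, which is a limit of the assay and not a number (the limit of < 40000 nM in this assay, at which 1 of the 2 values shown sits).
- compound 2 `COc1cc(/C=C/c2nc(NCc3ccccc3)c3sccc3n2)cc(OC)c1OC`; in this assay compound 2 gives > 1000000 nM, again a limit of the assay and not a number (the limit of > 1000000 nM in this assay, at which 1 of the 2 values shown sits).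

Compound 2 thus stands at the upper limit of what this assay reports, with no measurable value of its own. For the measured compounds named here, the single measured step, an at least 25-fold higher number from compound 1 to compound 2 (1.39 log units; beyond the scatter), runs from one limit to the other, so only its minimum size is known.

Compound 3 `COc1ccc(CNc2nc(/C=C/c3cc(OC)c(OC)c(OC)c3)nc3ccsc23)cc1` differs from compound 2 by methoxy in place of hydrogen on an aromatic carbon. Going by the values given here, no measured step covers this change directly; the one step available, an at least 25-fold higher number from compound 1 to compound 2 (1.39 log units; beyond the scatter), concerns a different replacement on the same nitrogen and shows only that the benzyl-bearing compound 2 falls at the limit. Nothing measured points to the methoxy group pulling the number back into the readable range, so no step beyond the scatter is expected in this assay.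

Compound 3 is therefore estimated at 1000000 nM, within a range of 300000 nM to 3000000 nM. This corresponds to an expected step of a number no higher from compound 2 to compound 3 (the limit leaves the size open), most probably reported once more as a limit.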

Compound 3, half-maximal inhibitory concentration: > 1000000 nM
Compound 3 gave a limit, no number; the forecaster's own chance of this, stated with the estimate: 80%; the middle value lies on the limit itself.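

Adding methoxy to the benzyl group, giving 4-methoxybenzyl, leaves the compound at the upper limit of this assay: the limit of > 1000000 nM in this assay, at which 2 of the 3 values shown sit.

The step between compound 2 and compound 3 cannot be read, as both values are limits, so no gain or loss can be assigned to the methoxy group at this position. The contrast on the nitrogen does appear with a second benzyl-type group, with an at least 25-fold higher number from compound 1 to compound 3 (1.39 log units; beyond the scatter), and the 4-methylphenyl of compound 1 remains the only nitrogen substituent shown that stays clear of the upper limit.

Open, on these data alone, is whether that contrast follows from the aromatic ring sitting directly on the nitrogen or from its 4-methyl group, a question that an unsubstituted phenyl or a 4-methoxyphenyl on the nitrogen would address. Also open, as far as these compounds go, is whether a different substituent at this position of the benzyl ring, such as a carboxylic acid or a dimethylamino group, would bring the number into the readable range, given that all three values shown are limits.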